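The compounds below may be only part of what the source reports. "The series", "measured", "known", "first", "only" and "open" are said of these compounds alone.

Of the compounds shown here, three have been tested in an assay on CHO cells for displacement of a labelled ligand from 5-hydroxytryptamine receptor 1D (Homo sapiens); on this read-out lower numbers stand for stronger inhibition and higher numbers for weaker inhibition. Compound 1 `OC[C@H](NC1CCN(CCCc2c[nH]c3ccc(-n4ccnc4)cc23)CC1)c1ccccc1` gives 0.7 nM there. Compound 2 `CN(C1CCN(CCCc2c[nH]c3ccc(-n4cnnc4)cc23)CC1)S(=O)(=O)c1ccccc1` gives 1.5 nM, and compound 3 `CN(Cc1ccc(S(C)(=O)=O)cc1)C1CCN(CCCc2c[nH]c3ccc(-n4cnnc4)cc23)CC1` gives 18 nM. Among these three numbers compound 2 stands second highest: compound 1 sits nearest, a little lower, while compound 3 lies furthest away. For the measured compounds named here, the one step known within the set runs from compound 2 to compound 3, where a 12-fold higher number from compound 2 to compound 3 (1.08 log units; beyond the scatter); that is a large move in this assay.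

Compound 4 `c1ccc(NCC2CCN(CCCc3c[nH]c4ccc(-n5cnnc5)cc34)CC2)nc1` has not yet been measured. It departs from compound 2 by the following change: ((pyridin-2-yl)amino)methyl in place of methyl(phenylsulfonyl)amino on a saturated ring carbon. Going by the values given here, the only measured step that touches the same position is the one from compound 2 to compound 3, and it showed that altering the group on that saturated ring carbon, so that the phenylsulfonyl is no longer present, made the number rise strongly. Compound 4 likewise does away with the phenylsulfonyl, so a rise beyond the scatter is expected from compound 2 to compound 4, though its size is uncertain because only a 12-fold higher number from compound 2 to compound 3 (1.08 log units; beyond the scatter) informs it. Compound 4 is therefore estimated at 8 nM, within the range 2 nM to 30 nM, which would amount to an expected step of a 5.3-fold higher number from compound 2 to compound 4 (0.73 log units; beyond the scatter).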

Compound 4, half-maximal inhibitory concentration: 1.7 nM
Compound 4: middle estimate off by 4.7-fold (0.67 log units), on the high side, outside the stated range (below it).
By their numbers in this assay, from the lowest: compound 1; then compounds 2 and 4 (each within the scatter of the next); then compound 3.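

In this assay, putting ((pyridin-2-yl)amino)methyl in place of methyl(phenylsulfonyl)amino on the saturated ring carbon leaves the number within the scatter (a 1.1-fold higher number from compound 2 to compound 4 (0.05 log units; within the scatter)). This shows that the phenylsulfonyl group can leave this position without the number rising beyond the scatter, even though the sulfur, both oxygens and the amine nitrogen attached to that ring carbon all go with it. The earlier step (a 12-fold higher number from compound 2 to compound 3 (1.08 log units; beyond the scatter)) therefore cannot be read as a general penalty for losing the phenylsulfonyl, and the same low range is reached here by a group that has a hydrogen-bond donor and a ring with a hetero atom, neither of which the leaving group has.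

The compounds shown leave open whether this reading would hold for ((phenyl)amino)methyl or ((pyrimidin-2-yl)amino)methyl at the same ring carbon, so the part played by the pyridine nitrogen cannot be judged. Nothing measured here explains why two such different groups read alike in this assay.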